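Acyl variation on the pyrazole amide in an EP1 series

The compounds below may be only part of what the source reports. "The series", "measured", "known", "first", "only" and "open" are said of these compounds alone.

The series is read in an assay on CHO-K1 cells for displacement of a labelled ligand from prostaglandin E2 receptor EP1 subtype (Homo sapiens); on this read-out higher numbers stand for weaker inhibition and lower numbers for stronger inhibition. Compound 1 `Cc1cc(C(=O)O)nn1Cc1cc(Br)ccc1OCc1ccccc1` gives 6.31 nM, and compound 3 `Cc1cc(NC(=O)C2CCCC2)nn1Cc1cc(Cl)ccc1OCC(C)C` gives 25.1 nM. Compound 2 `CC(=O)Nc1cc(C)n(Cc2cc(Cl)ccc2OCc2ccccc2)n1` gives 316 nM, the highest of the three numbers; its gap to compound 3 and its wider gap to compound 1 both lie beyond the scatter, so compound 2 stands as the weakest inhibitor among the measured compounds. Going by the values given here, compound 3 differs from compound 2 in more than one place, so those two values show only that the change away from the acetamide, together with the other change, goes with a markedly lower number.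

Compound 4 `Cc1cc(NC(=O)OCC(C)C)nn1Cc1cc(Cl)ccc1OCc1ccccc1` has not yet been measured. It differs from compound 2 in one place: isobutoxy in place of methyl on a carbonyl carbon. Among the compounds with values here, no measured pair shows exactly this change, so the size of the step can only be estimated. Because compound 3 gives 25.1 nM with a different group on the carbonyl carbon, a downward step from compound 2 to compound 4 of moderate size, beyond the scatter, is expected; the estimated step is a 5.0-fold lower number from compound 2 to compound 4 (0.70 log units; beyond the scatter). Compound 4 is accordingly expected to give 63 nM, with a range from 16 nM to 250 nM.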

Compound 4, half-maximal inhibitory concentration: 25.1 nM
Compound 4: the middle estimate sits 2.5-fold (0.40 log units) above what was measured; the measured number falls inside the stated range.
By their numbers in this assay, from the lowest: compound 1; then compounds 3 and 4 (each within the scatter of the next); then compound 2.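

In this assay, the carbonyl carbon on the amide-type nitrogen now stands out as a place that matters by itself: isobutoxy in place of methyl gives a 13-fold lower number from compound 2 to compound 4 (1.10 log units; beyond the scatter), with the rest of the structure unchanged. The earlier compounds shown here could not show this, as no two of them differed in one place only. This single step still changes two things at once, since acetamido to (isobutoxycarbonyl)amino both lengthens the group from 1 heavy atom to 5 and brings in an oxygen on the carbonyl carbon. The data shown offer no measured basis for explaining the size of this step.

The compounds shown leave open whether the oxygen, the branched chain or both go with the lower number: a 3-methylbutanoyl group would keep the carbon chain without the oxygen, and a methoxycarbonyl group would keep the oxygen without the chain. Also open, as far as these compounds go, is how an unbranched butoxy group or a urea built on a dimethylamine would read at this same place on the shared core.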